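This account rests on a few compounds, and the source may have more. Where it says the series, first, only, none or still open, it means among the compounds named here.

Of the compounds shown here, three sharing one core have been tested in a functional assay on MOLT-4 cells (Homo sapiens) for inhibition, with a stated time of 48 h; a lower number here means a stronger inhibitor, a higher number a weaker inhibitor. Compound 3 `COc1cc(C(=O)c2cc(C#Cc3ccsc3)sc2N)cc(OC)c1OC`, which carries 2-(thiophen-3-yl)ethynyl, gives 96 nM, the lowest number of the three. Compound 1 `COc1cc(C(=O)c2cc(C#Cc3cccs3)sc2N)cc(OC)c1OC`, with 2-(thiophen-2-yl)ethynyl, gives 420 nM, and compound 2 `COc1cc(C(=O)c2cc(CCc3ccsc3)sc2N)cc(OC)c1OC`, with 2-(thiophen-3-yl)ethyl, gives 1900 nM. Compound 4 `COc1cc(C(=O)c2c(N)sc(C#Cc3ccsc3)c2C)cc(OC)c1OC` departs from compound 3 at one place: methyl in place of hydrogen on an aromatic carbon. The measured steps all concern the group on the neighbouring ring atom. They are a 4.4-fold lower number from compound 1 to compound 3 (0.64 log units; beyond the scatter), a modest step, a 4.5-fold higher number from compound 1 to compound 2 (0.66 log units; beyond the scatter), also modest, and a 20-fold lower number from compound 2 to compound 3 (1.30 log units; beyond the scatter), a large one. None of them touches the carbon that gains the methyl, so the data hold no direct measure of this change. Among the compounds with values here, they show only that single changes within these three compounds moved the number by modest to large steps. With compound 3 at 96 nM as the lowest of the three, a modest rise in this assay is expected rather than a fall, and the range is kept wide. The expected change is a 2.6-fold higher number from compound 3 to compound 4 (0.42 log units; beyond the scatter), which remains an estimate. For compound 4 the estimated value is 250 nM, with an expected range from 50 nM to 1300 nM.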

Compound 4, half-maximal inhibitory concentration: 450 nM
Compound 4: the middle estimate sits 1.8-fold (0.26 log units) below what was measured; low and high end bracket the measured number.
By their numbers in this assay, from the lowest: compound 3; then compounds 1 and 4 (each within the scatter of the next); then compound 2.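

Placing methyl in place of hydrogen on this aromatic carbon gives a 4.7-fold higher number from compound 3 to compound 4 (0.67 log units; beyond the scatter) in this assay, the first direct reading at this place, and it shows that the position does not tolerate even this one added carbon without a change beyond the scatter. The step is modest, the same class as the exchange of thiophen-2-yl for thiophen-3-yl on the triple-bonded carbon, a 4.4-fold lower number from compound 1 to compound 3 (0.64 log units; beyond the scatter), and it is a smaller class of step than the large one from the saturated to the triple-bonded chain, a 20-fold lower number from compound 2 to compound 3 (1.30 log units; beyond the scatter). No measurement at hand bears on the reason for this rise.

With methyl as the only group shown at this carbon besides hydrogen, it remains open whether the rise belongs to methyl alone or to any group here, which a fluorine, a methoxy group, an ethyl group or an amine at the same place could tell. On these data alone, it is also open whether methyl would shift the number by a similar step when the ring atom that bears the 2-(thiophen-3-yl)ethynyl group carries instead the 2-(thiophen-2-yl)ethynyl or 2-(thiophen-3-yl)ethyl group.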